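Changing the aryl group on a serine-derived imine

A few compounds are considered here, and "the series" means these few. Any claim that something is new, unique, unknown or untested is made for them only; others in the source may bear on it.

Measured compounds:
compound 1 `CCCCCCCCCCCCCCNC(=O)[C@H](CO)/N=C/c1cccc(OC)c1`, which in an ADME assay on HEK293 cells (Homo sapiens) for cytotoxicity (on this read-out higher numbers stand for weaker inhibition and lower numbers for stronger inhibition), gives 77300 nM
compound 2 `CCCCCCCCCCCCCCNC(=O)[C@H](CO)/N=C/c1ccc(OC)cc1`, which in this assay gives 81700 nM
compound 3 `CCCCCCCCCCCCCCNC(=O)[C@H](CO)/N=C/c1ccccc1Cl`, which in this assay gives 94900 nM

All three share the same long chain, amide and hydroxymethyl-bearing core and differ only in the aromatic ring attached to the carbon with a double bond to nitrogen. The steps between them are small: a 1.1-fold higher number from compound 1 to compound 2 (0.02 log units; within the scatter), a 1.2-fold higher number from compound 1 to compound 3 (0.09 log units; within the scatter) and a 1.2-fold higher number from compound 2 to compound 3 (0.07 log units; within the scatter). Compound 3 therefore stands within the scatter of both compound 1 and compound 2, and none of the three can be set apart from the others.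

Compound 4 `CCCCCCCCCCCCCCNC(=O)[C@H](CO)/N=C/c1ccc(O)cc1` carries the change (4-hydroxyphenyl in place of 2-chlorophenyl on a carbon with a double bond to nitrogen). Every measured step that swaps this ring bears on it, and each was within the scatter, although none introduced a hydrogen-bond donor, so the new ring is a step into unmapped ground. With that caveat, no step beyond the scatter is expected in this assay, and the expected step is a 1.1-fold lower number from compound 3 to compound 4 (0.05 log units; within the scatter). Compound 4 is estimated to give 85000 nM, with a range from 45000 nM to 160000 nM.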

Compound 4, half-maximal inhibitory concentration: 71700 nM
Compound 4: middle estimate off by 1.2-fold (0.07 log units), on the high side; the measured number falls inside the stated range.
By their numbers in this assay, from the lowest: compounds 4, 1, 2 and 3 (each within the scatter of the next).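

For the compounds shown here, the 4-hydroxyphenyl ring is the first group at this position to bring a hydrogen-bond donor, and in this assay this addition leaves the number within the scatter of the 2-chlorophenyl compound (a 1.3-fold lower number from compound 3 to compound 4 (0.12 log units; within the scatter)) and of the 3-methoxyphenyl compound (a 1.1-fold lower number from compound 1 to compound 4 (0.03 log units; within the scatter)). The comparison with compound 2 is the tightest in the set. Going by these compounds alone, only one group changes, hydrogen in place of methyl on an oxygen on an aromatic ring, and this step also stays within the scatter (a 1.1-fold lower number from compound 2 to compound 4 (0.06 log units; within the scatter)). Across these four compounds, then, the ring on the carbon with a double bond to nitrogen has taken a chlorine, a methoxy group and now a hydroxyl group without any step beyond the scatter, and no measurement offered here accounts for this flat result.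

Still open, going by these compounds, is whether a stronger departure on this ring, such as an amine or a carboxylic acid, would produce a step beyond the scatter. On these data alone, the long chain and the hydroxymethyl group stay the same throughout, so the effect of a shorter chain or of a different group in place of the hydroxymethyl remains unknown.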